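A few compounds are considered here, and "the series" means these few. Any claim that something is new, unique, unknown or untested is made for them only; others in the source may bear on it.

Among the compounds with values here, compound 2 `CCCCNc1nc(N)nc2c1CN(Cc1c(Cl)cccc1Cl)CC2` gives 0.14 uM in an assay on HEK293 cells for agonist activity at Toll-like receptor 8 (Homo sapiens), read by a luciferase reporter, with a stated time of 6 h (a lower number here means that less compound is needed, a higher number that more compound is needed for the effect), the higher of the two numbers measured so far. Compound 1 `CCCCNc1nc(N)nc2c1CN(Cc1ccccc1)CC2` gives 0.06 uM, and the step of a 2.3-fold higher number from compound 1 to compound 2 (0.37 log units; beyond the scatter) went with a 2,6-dichlorophenyl in place of phenyl on a saturated chain carbon bound to an amine nitrogen in a ring. Compound 3 `CCCCNc1nc(N)nc2c1CN(Cc1cc(F)cc(F)c1)CC2` differs from compound 2 by 3,5-difluorophenyl in place of 2,6-dichlorophenyl on a saturated chain carbon bound to an amine nitrogen in a ring. Within the data shown here, only that one measured step bears on this change, and it was modest. A small step of a 1.4-fold lower number from compound 2 to compound 3 (0.15 log units; within the scatter) is therefore expected, with the new number likely to fall between the two already measured. Compound 3 is estimated at 0.1 uM, within 0.03 uM to 0.3 uM.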

Compound 3, minimum effective concentration: 0.23 uM
Estimate against measurement, compound 3: 2.3-fold (0.36 log units) below; low and high end bracket the measured number.
By their numbers in this assay, from the lowest: compound 1; then compounds 2 and 3 (each within the scatter of the next).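

The 3,5-difluorophenyl and 2,6-dichlorophenyl groups cannot be told apart in this assay, since a 1.6-fold higher number from compound 2 to compound 3 (0.22 log units; within the scatter) stays inside the usual scatter. The comparison with plain phenyl is clearer: a 3.8-fold higher number from compound 1 to compound 3 (0.58 log units; beyond the scatter) means that both halogen-bearing rings, on a saturated chain carbon bound to an amine nitrogen in a ring, need more compound than compound 1. Nothing available gives a reason for these steps. Still open, on these data alone, is whether a phenyl ring carrying a single fluorine, a methoxy group or an amine would match compound 1.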